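The compounds below may be only part of what the source reports. "The series", "measured", "known", "first", "only" and "open" are said of these compounds alone.

Measured so far in a functional assay on SN12C cells (Homo sapiens) for inhibition, read by sulforhodamine B assay, with a stated time of 48 h, tested at 10 uM; on this read-out higher numbers stand for a weaker effect at the one concentration tested and lower numbers for a stronger effect:
compound 1, `COc1cc(Cl)cc(-c2nn(-c3cccc(NC(=O)Nc4cc(C(F)(F)F)cc(C(F)(F)F)c4)c3)cc2-c2ccncc2)c1`: 9.32%
compound 2, `COc1cc(Cl)cc(-c2nn(-c3cccc(NC(=O)Nc4ccc(Cl)c(Cl)c4)c3)cc2-c2ccncc2)c1`: 15.5%

In this assay compound 2 gives 15.5%, while compound 1 gives 9.32%; the two numbers lie within the usual scatter of each other, so neither can be called the stronger. Compound 3, `COc1cc(Cl)cc(-c2nn(-c3cccc(NC(=O)Nc4cccc(C(F)(F)F)c4)c3)cc2-c2ccncc2)c1`, has not yet been measured. It differs from compound 2 in one place: 3-(trifluoromethyl)phenyl in place of 3,4-dichlorophenyl on an amide-type nitrogen. Among the measured compounds shown here, no measured pair shows this change, so its size is open. Because compound 2 gives 15.5%, a step of modest size in this assay is expected, in no firm direction. Compound 3 is expected to give 14%, within 5% to 30%. The expected step is a number 1.5 percentage points lower from compound 2 to compound 3 (within the scatter).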

Compound 3, a percentage reported as activity, at one concentration (the size of the read-out at that concentration, not a potency): 13.9%
Estimate against measurement, compound 3: 0.1 percentage points above; measured number inside the range.
By their numbers in this assay, from the lowest: compounds 1, 3 and 2 (each within the scatter of the next).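

In this assay, 3-(trifluoromethyl)phenyl in place of 3,4-dichlorophenyl on the amide-type nitrogen gives a number 1.6 percentage points lower from compound 2 to compound 3 (within the scatter), and hydrogen in place of trifluoromethyl on an aromatic carbon gives a number 4.6 percentage points higher from compound 1 to compound 3 (within the scatter). The three aromatic groups at this position therefore cannot be told apart in this assay, so the earlier single comparison now extends to a third group and to a second kind of change.

Whether an aromatic ring carrying an amine or a carboxylic acid at this position would also match them remains open, and no measurement at hand explains the result.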